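Replacing cyano with hydroxy in compound 3

The source may report more compounds than this note shows. Statements on the series, on what has been measured and on what is new or still open speak of the compounds shown alone.

Measured in a functional assay on CLL cells (Homo sapiens) for cytotoxicity, read by MTT assay, with a stated time of 48 h; a higher number here means that more compound is needed for the effect, a lower number that less compound is needed:
Compound 1 `C=C(CC)C(=O)c1ccc(OCC(=O)Nc2ccc3nc[nH]c3c2)c(Cl)c1Cl`: 3200 nM
Compound 2 `C=C(CC)C(=O)c1ccc(OCC(=O)Nc2ccc(C(C)=O)cc2)c(Cl)c1Cl`: 3900 nM
Compound 3 `C=C(CC)C(=O)c1ccc(OCC(=O)Nc2ccc(C#N)cc2)c(Cl)c1Cl`: 7800 nM

Compound 3 needs more compound than compound 1, with a 2.4-fold higher number from compound 1 to compound 3 (0.39 log units; beyond the scatter), but it stays within the scatter of compound 2, with a 2.0-fold higher number from compound 2 to compound 3 (0.30 log units; within the scatter). Compound 4 `C=C(CC)C(=O)c1ccc(OCC(=O)Nc2ccc(O)cc2)c(Cl)c1Cl` carries hydroxy in place of cyano on an aromatic carbon. Going by the values given here, no measured compound has this hydroxy group. The nearest guide is the change of group at the same place, a 2.0-fold higher number from compound 2 to compound 3 (0.30 log units; within the scatter), alongside a 1.2-fold higher number from compound 1 to compound 2 (0.09 log units; within the scatter). These steps are small, so this assay is expected to show no change beyond the scatter, and the expected step is a 1.7-fold lower number from compound 3 to compound 4 (0.24 log units; within the scatter). The estimate for compound 4 is 4500 nM, with an expected range from 2000 nM to 10000 nM.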

Compound 4, half-maximal effective concentration: 6400 nM
Beside the measured number, compound 4's estimate is 1.4-fold (0.15 log units) below it; the measured number falls inside the stated range.
By their numbers in this assay, from the lowest: compounds 1, 2, 4 and 3 (each within the scatter of the next, the first and the last beyond it).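

Putting hydroxy in place of cyano adds a hydrogen-bond donor at this ring position, yet this assay shows no change beyond the scatter (a 1.2-fold lower number from compound 3 to compound 4 (0.09 log units; within the scatter)). Hydroxy in place of acetyl also stays within the scatter (a 1.6-fold higher number from compound 2 to compound 4 (0.22 log units; within the scatter)), as does 4-hydroxyphenyl in place of 1H-benzimidazol-6-yl (a 2.0-fold higher number from compound 1 to compound 4 (0.30 log units; within the scatter)). Compound 4 therefore sits within the scatter of all three earlier compounds, and only compound 1 and compound 3 remain separated beyond it.

As far as these compounds go, whether an amine or a carboxylic acid at this position would shift the number remains open. No measurement shown explains why these groups give such similar numbers.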